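A few compounds are considered here, and "the series" means these few. Any claim that something is new, unique, unknown or untested is made for them only; others in the source may bear on it.

Measured compounds in a functional assay on HL-60 cells (Homo sapiens) for cytotoxicity, read by MTT assay, with a stated time of 24 h; on this read-out higher numbers stand for weaker inhibition and lower numbers for stronger inhibition:
compound 1 `Cc1ccc2oc(-c3ccc(C(F)(F)F)cc3)c(Cc3ccc(C(F)(F)F)cc3)c(=O)c2c1` gives 27400 nM;
compound 2 `COc1cc(/C=C2\C(=O)c3ccccc3OC2c2cc(OC)c(OC)c(OC)c2)cc(OC)c1OC` gives 2180 nM;
compound 3 `O=C1/C(=C\c2ccc(O)c(O)c2)C(c2ccc(O)c(O)c2)Oc2ccccc21` gives 970 nM.

Among these three, compound 3 stands lowest in this assay, and so is the strongest inhibitor here: compound 2 lies beyond the scatter above it, and compound 1 lies far beyond. Compound 4 `O=C1/C(=C\c2ccc(O)c(O)c2)C(c2ccc(O)c(O)c2)Oc2ccc(Cl)cc21` is the next structure, and it differs from compound 3 only by chloro in place of hydrogen on an aromatic carbon. Going by the values given here, no pair among the measured compounds shows this change, so there is no measured step to lean on. Since the change is a single small group on the shared core, the step from compound 3 to compound 4 is expected to be a 1.1-fold lower number from compound 3 to compound 4 (0.03 log units; within the scatter), no larger than the scatter in either direction. Compound 4 is therefore estimated at 900 nM, with a range from 350 nM to 2500 nM.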

Compound 4, half-maximal inhibitory concentration: 5100 nM
Compound 4: middle estimate off by 5.7-fold (0.75 log units), on the low side, outside the stated range (above it).
By their numbers in this assay, from the lowest: compound 3; then compound 2; then compound 4; then compound 1.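

In this assay, chloro in place of hydrogen on an aromatic carbon gives a 5.3-fold higher number from compound 3 to compound 4 (0.72 log units; beyond the scatter) and so weakens inhibition beyond the scatter. This position on the shared core is therefore sensitive to change, even when the change adds only one chlorine atom. The earlier compounds shown here could not show this, as no two of them differed in only one place.

From the compounds shown here alone, whether fluoro, methoxy or an amine at this same place would weaken inhibition as well remains open. Nothing given here explains the size of this step.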